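Swapping piperidin-2-yl for 3-aminophenyl on the shared core

The compounds below may be only part of what the source reports. "The series", "measured", "known", "first", "only" and "open" are said of these compounds alone.

Measured so far:
compound 1, `O=C(O)c1cccc(CNc2cc(C(F)(F)F)cc3[nH]ncc23)c1`: 11%
compound 2, `FC(F)(F)c1cc(NC[C@@H]2CCCCN2)c2cn[nH]c2c1`: 32%
compound 3, `FC(F)(F)c1cc(NC[C@H]2CCCCN2)c2cn[nH]c2c1`: 19%

In an assay for inhibition of Indoleamine 2,3-dioxygenase 1 (Homo sapiens), with stated times of 10 min and 60 min, tested at 10 uM (a higher number here means a stronger effect of the compound at the concentration tested, a lower number a weaker effect), compound 3 gives 19% and stands second highest of the three numbers; its nearest neighbour is compound 1, which is within the scatter, while compound 2 lies beyond it. For the measured compounds named here, the only step measured between neighbours is a number 13 percentage points lower from compound 2 to compound 3 (beyond the scatter), and it rests solely on (the fact that compounds 2 and 3 differ only in the configuration as drawn).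

Compound 4, `Nc1cccc(CNc2cc(C(F)(F)F)cc3[nH]ncc23)c1`, has not been measured. It differs from compound 3 by 3-aminophenyl in place of piperidin-2-yl on a saturated chain carbon bound to a nitrogen on an aromatic ring. Going by the values given here, no measured step concerns this change: the step between compound 2 and compound 3 is one of configuration alone and says nothing about replacing the saturated ring with an aromatic one. The best guide is that all three measured compounds fall within a narrow band of weak inhibition. In this assay compound 4 is therefore expected to give about 18%, with a range from 5% to 35%. The step of a number 1 percentage points lower from compound 3 to compound 4 (within the scatter) is thus estimated to stay within the scatter.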

Compound 4, a percentage reported as inhibition, at one concentration (the size of the read-out at that concentration, not a potency): 24%
For compound 4 the middle estimate is 6 percentage points below the measured one; the range from low to high includes it.
By their numbers in this assay, from the lowest: compounds 1, 3, 4 and 2 (each within the scatter of the next, the first and the last beyond it).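

In this assay, the step of a number 5 percentage points higher from compound 3 to compound 4 (within the scatter) and the step of a number 8 percentage points lower from compound 2 to compound 4 (within the scatter) both stay within the scatter, so at this position 3-aminophenyl is not told apart from either drawn form of piperidin-2-yl. Compound 4 has no defined stereocentre, yet it is not separated from compound 2 or compound 3, although those two are separated from each other. For the compounds shown here, the change on the aromatic ring does register: the step of a number 13 percentage points higher from compound 1 to compound 4 (beyond the scatter) is beyond the scatter and is the first measured step for amino in place of carboxy on an aromatic carbon. Nothing given here bears on the cause of these steps. Still open, on these data alone, is whether a hydroxyl or a nitrile in place of the amino group, or a longer chain in place of the saturated chain carbon, would move the number beyond the scatter of compound 4.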